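The source may report more compounds than this note shows. Statements on the series, on what has been measured and on what is new or still open speak of the compounds shown alone.

Measured compounds:
- compound 1, `CNc1nccc(N2CC[C@H](NC(=O)Nc3ccc(C)c(Cl)c3)C2)n1` — 99.3%
- compound 2, `CNc1nccc(N2CC[C@H](NC(=O)Nc3ccc(CN4CCCC4)c(C(F)(F)F)c3)C2)n1` — 86.5%

In an ADME assay on a cell-free system (plasma, Homo sapiens) for protein binding, compound 1 gives 99.3%, the lowest unbound fraction of the two measured compounds. Compound 2 gives 86.5% in this assay, a clearly larger unbound fraction, and the gap between these two values lies well beyond the scatter of repeated measurements.

The step considered here goes from compound 1 to compound 3, `CNc1nccc(N2CC[C@H](NC(=O)Nc3cccc(OC)c3)C2)n1`, whose structure differs from compound 1 in one place: 3-methoxyphenyl in place of 3-chloro-4-methylphenyl on an amide-type nitrogen. Going by the values given here, no pair of measured compounds shows this change, so its effect in this assay cannot be read off directly. Compound 3 lacks the chlorine of compound 1 and carries one hydrogen-bond acceptor where compound 1 has none. On that basis a step toward a larger unbound fraction is expected, beyond the scatter but smaller than the gap between compound 1 and compound 2. Compound 3 is therefore estimated to bind at 96.5%, with a plausible range from 91% to 98.8%, a shift of a 5.0-fold higher unbound fraction from compound 1 to compound 3 (0.70 log units; beyond the scatter) that is expected rather than known.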

Compound 3, plasma protein binding: 96.7%
Estimate against measurement, compound 3: 1.1-fold (0.03 log units) (unbound fraction) above; the range from low to high includes it.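

In this assay the group on the amide-type nitrogen now has a measured single-change effect: 3-methoxyphenyl in place of 3-chloro-4-methylphenyl, with the shared core unchanged, gives a 4.7-fold higher unbound fraction from compound 1 to compound 3 (0.67 log units; beyond the scatter) and thus shows that this position can alter the read-out even when the incoming group is no smaller by heavy-atom count. Both groups hold 8 heavy atoms and one six-membered aromatic ring of carbon only, while the change removes the chlorine and takes the hydrogen-bond acceptors of the group from 0 to 1. Going by these compounds alone, with only this one pair, nothing here assigns the step to the lost chlorine, the lost methyl or the added methoxy oxygen.

The compounds shown leave open how much of the step each part of the change carries, as no aryl group holding the chlorine without the methyl, or the methyl without the chlorine, stands among them. They also leave open how this assay would respond to a carboxylic acid or a morpholine on the aromatic ring at this position.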